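Changing the tail of compound 1: a cytotoxicity forecast

The source may hold more compounds than are shown below. What is called first, only, known or untested is meant among the compounds shown, and "the series" means these compounds.

Compound 1 `CCCNC(=O)Nc1cc2nc(C3CCCCC3)[nH]c2cc1N1CCCC1` was tested in an ADME assay on Vero cells (Chlorocebus sabaeus) for cytotoxicity, read by resazurin assay, with a stated time of 3 days; a higher number here means a weaker inhibitor, a lower number a stronger inhibitor. In this assay compound 1 stops at > 100 ug/mL, which is a limit of the assay and not a number. Compound 2 `CCCCOC(=O)Nc1cc2nc(C3CCCCC3)[nH]c2cc1N(C)C` also stops at the limit > 100 ug/mL. Compound 3 `CCOc1ccc(C(=O)Nc2cc3nc(C4CCCCC4)[nH]c3cc2N(CC)CC)cc1` likewise sits at the limit > 100 ug/mL. All three stand at the limit of > 100 ug/mL in this assay, at which 3 of the 3 values shown sit, so none shows measurable cytotoxicity here. Compound 4 `CCOCCOC(=O)Nc1cc2nc(C3CCCCC3)[nH]c2cc1N1CCCC1` differs from compound 1 in one place: 2-ethoxyethoxy in place of propylamino on a carbonyl carbon. No step between measured compounds covers this change, so no measured direction exists for it; because every shown value sits at the limit of > 100 ug/mL in this assay, at which 3 of the 3 values shown sit, the step is expected to be none beyond the scatter, namely a step that the limit leaves unreadable from compound 1 to compound 4. Compound 4 is therefore estimated at 150 ug/mL, between 70 ug/mL and 400 ug/mL, most likely reported again only as a limit.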

Compound 4, half-maximal inhibitory concentration: > 100 ug/mL
Compound 4 gave a limit, no number; the forecaster's own chance of this, stated with the estimate: 85%; the middle value does not contradict the limit.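

Compound 4, like compound 1, gives only a limit of the assay and not a number, so no step between them can be read: the limit of > 100 ug/mL in this assay, at which 4 of the 4 values shown sit.

The compounds shown leave open at what concentration any of them would show cytotoxicity in this assay.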